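The source may hold more compounds than are shown below. What is called first, only, known or untested is meant among the compounds shown, and "the series" means these compounds.

Compounds measured so far:
- Compound 1, `COCC(C(=O)N1CCN(c2cccc(C(F)(F)F)c2)CC1)N1C(=O)CCC1=O`, in a functional assay on the whole organism (strain Swiss) with Mus musculus as the target, in the maximal electroshock model, with a stated time of 1 h, at a dose of 300 mg/kg by the intraperitoneal route (on this read-out lower numbers stand for a weaker effect and higher numbers for a stronger effect at the one dose given), compound 1 gives 100%.
- Compound 2, `CC(C(=O)N1CCN(c2ccccc2)CC1)N1C(=O)CCC1=O`, in this assay compound 2 gives 50%.
- Compound 3, `CC(C(=O)N1CCN(c2cccc(F)c2)CC1)N1C(=O)CCC1=O`, in this assay compound 3 gives 75%.

Compound 3 thus stands second highest of the three numbers, above compound 2 and below compound 1. Compound 4, `CC(C(=O)N1CCN(c2cccc(C(F)(F)F)c2)CC1)N1C(=O)CCC1=O`, differs from compound 3 in one place: trifluoromethyl in place of fluoro on an aromatic carbon. For the measured compounds named here, the only measured step, a number 25 percentage points higher from compound 2 to compound 3 (beyond the scatter), concerns the same aromatic position and was modest. Going by the values given here, compound 1, which also carries trifluoromethyl at that position, gives 100% in this assay; no step to it is available. For compound 4 an increase of about a number 15 percentage points higher from compound 3 to compound 4 (beyond the scatter) is therefore expected in this assay. Compound 4 is estimated at 90%, within 70% to 100%.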

Compound 4, a percentage reported as activity, at one dose (the size of the read-out at that dose, not a potency): 100%
Estimate against measurement, compound 4: 10 percentage points below, within the range that was stated.
By their numbers in this assay, from the lowest: compound 2; then compound 3; then compounds 1 and 4 (each within the scatter of the next).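

In this assay, trifluoromethyl at this aromatic position goes beyond fluoro, with a number 25 percentage points higher from compound 3 to compound 4 (beyond the scatter), and measured against hydrogen at the same carbon the change gives a number 50 percentage points higher from compound 2 to compound 4 (beyond the scatter). With trifluoromethyl on the ring, hydrogen in place of methoxy on the saturated chain carbon leaves the read-out unmoved, with no change at the digits printed from compound 1 to compound 4 (within the scatter). No measured evidence accounts for these steps. Still open, as far as these compounds go, is how an amine or a nitrile at the same aromatic position, or a longer chain on the saturated chain carbon, would fare in this assay.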